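The source may hold more compounds than are shown below. What is called first, only, known or untested is meant among the compounds shown, and "the series" means these compounds.

Compound 2 `CCCCCCCCCC(=O)Nc1nnc(S[C@@H]2O[C@H](COC(C)=O)[C@H](OC(C)=O)[C@H](OC(C)=O)[C@H]2OC(C)=O)s1` gives 34400 nM in a functional assay on DU-145 cells (Homo sapiens) for cytotoxicity, read by MTT assay, with a stated time of 24 h (a higher number here means a weaker inhibitor, a lower number a stronger inhibitor), the highest of the two numbers recorded in the series. Compound 3 `CCCCCCCC/C=C\CCCCCCCCCCCC(=O)Nc1nnc(S[C@@H]2O[C@H](COC(C)=O)[C@H](OC(C)=O)[C@H](OC(C)=O)[C@H]2OC(C)=O)s1` gives 28400 nM, the step being a 1.2-fold lower number from compound 2 to compound 3 (0.08 log units; within the scatter). Compound 1 `CCCCCCCCCCCC(=O)Nc1nnc(S[C@@H]2O[C@H](CO)[C@H](O)[C@H](O)[C@H]2O)s1` is reported in this assay as "not active" (no number reported), without a number. Compound 4 `CCCCCC(=O)Nc1nnc(S[C@@H]2O[C@H](COC(C)=O)[C@H](OC(C)=O)[C@H](OC(C)=O)[C@H]2OC(C)=O)s1` differs from compound 2 by hydrogen in place of butyl on a saturated chain carbon, five bonds along the chain from a carbonyl carbon. Going by the values given here, the only measured step touching the acyl chain, a 1.2-fold lower number from compound 2 to compound 3 (0.08 log units; within the scatter), lengthened it without effect beyond the scatter; compound 4 shortens it instead, and no measured step covers that direction. Nothing seen points to a move beyond the scatter, so for compound 4 the expected step is a 1.2-fold higher number from compound 2 to compound 4 (0.07 log units; within the scatter). Compound 4 is therefore estimated at 40000 nM in this assay, with a range from 15000 nM to 120000 nM, and a real chance that only a limit is reported.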

Compound 4, half-maximal inhibitory concentration: "not active" (no number reported)
No number was reported for compound 4, so the estimate cannot be set against anything.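

In this assay, going by these compounds alone, compound 4 gives "not active" (no number reported), so no step from compound 2 to compound 4 can be read, and no evidence on hand bears on this result. The compounds shown leave open how shortening the acyl chain affects the value.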